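The compounds below may be only part of what the source reports. "The series", "measured", "known", "first", "only" and "open" are said of these compounds alone.

Compound 1, `Cc1ccc(C2=NN(C3=NC(c4ccccc4)CS3)C(c3ccc4ccccc4c3)C2)cc1`, is one of three measured members of this set. In a functional assay on BGC-823 cells (Homo sapiens) for inhibition, read by CCK-8 assay, with a stated time of 48 h (a higher number here means a weaker inhibitor, a lower number a stronger inhibitor), compound 1 gives 8940 nM. Compound 2, `COc1ccc(C2=NN(C3=NC(c4ccccc4)CS3)C(c3ccc4ccccc4c3)C2)cc1`, carries methoxy in place of methyl on an aromatic carbon relative to compound 1, and in this assay compound 2 gives 7250 nM. The step is a 1.2-fold lower number from compound 1 to compound 2 (0.09 log units; within the scatter), so the two values cannot be told apart on this evidence. Compound 3, `Cc1ccc(C2=NN(C3=NC(=O)CS3)C(c3cccc4ccccc34)C2)cc1`, is built on a different core; how the core of compound 3 differs from the core of compound 1 is not broken down here. In this assay compound 3 gives 10000 nM. Its separation from compound 1 and from compound 2 is within the scatter in each case, so none of the three can be ranked against the others.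

Compound 4, `COc1ccc(C2=NN(C3=NC(=O)CS3)C(c3cccc4ccccc34)C2)cc1`, is not yet measured. It differs from compound 3 by methoxy in place of methyl on an aromatic carbon, and the place is the same as that of the change from compound 1 to compound 2, so this is the same change made a second time, now on the core of compound 3. Within the data shown here, the only guide to its size is the earlier pair, where the step was a 1.2-fold lower number from compound 1 to compound 2 (0.09 log units; within the scatter). On that basis the step is expected to be small, a 1.2-fold lower number from compound 3 to compound 4 (0.07 log units; within the scatter), because compound 3 gives 10000 nM and the earlier change moved the number only within the scatter. Compound 4 is therefore estimated at 8500 nM in this assay, with a plausible range from 4000 nM to 20000 nM.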

Compound 4, half-maximal inhibitory concentration: 8210 nM
Compound 4: the middle estimate sits 1.0-fold (0.02 log units) above what was measured; the range from low to high includes it.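

In this assay, the change from 4-methylphenyl to 4-methoxyphenyl on the core of compound 3 gives a 1.2-fold lower number from compound 3 to compound 4 (0.09 log units; within the scatter), so compound 3 and compound 4 cannot be told apart on this evidence. Among these compounds, the same change on the core of compound 1 gave a step of matching size, and the two steps cannot be separated: the same change on two cores in this assay, a 1.2-fold lower number (0.09 log units; within the scatter) from compound 1 to compound 2 and a 1.2-fold lower number (0.09 log units; within the scatter) from compound 3 to compound 4, 1.0-fold (0.01 log units) apart, within the scatter of two such steps This shows that the change carries across these two cores without any detectable difference, but as each step lies within the scatter, the agreement is only between two steps that cannot themselves be told from no step, and it shows neither that methoxy in place of methyl has a real effect on either core nor that the same would hold on any third core.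

The compounds shown hold only methyl and methoxy at this place, so it stays open whether an amine, a carboxylic acid or a longer chain there would give a step beyond the scatter. Also open is what the core itself contributes in this assay, as compound 1 and compound 3 differ in more than one place and no pair shown isolates a single change to the core.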